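The compounds below may be only part of what the source reports. "The series", "measured", "known", "first", "only" and "open" are said of these compounds alone.

Measured so far in an assay on isolated protein (Cavia porcellus) with Sigma non-opioid intracellular receptor 1 (Homo sapiens) as the target, read by radioligand binding; on this read-out lower numbers stand for stronger inhibition and higher numbers for weaker inhibition:
compound 1, `O=c1cc(-c2ccccc2)oc2cccc(OCCCCCCCN3CCC(O)CC3)c12`, gives 65 nM
compound 2, `CN(C)CCCCCCCOc1ccc2oc(-c3ccccc3)cc(=O)c2c1`, gives 188 nM
compound 3, `O=c1cc(-c2ccccc2)oc2ccc(OCCCCCCN3CCC(O)CC3)cc12`, gives 121 nM

Among these three, compound 2 has the highest number. Compound 3 lies closest to it, and the step between them, a 1.6-fold lower number from compound 2 to compound 3 (0.19 log units; within the scatter), stays within the usual scatter of this assay. Compound 1 sits further off, and a look at the two values shows compound 1 with the clearly lower number.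

Compound 4, `O=c1cc(-c2ccccc2)oc2ccc(OCCCCCCN3CCCCC3)cc12`, has not yet been measured. It differs from compound 2 by piperidin-1-yl in place of (dimethylamino)methyl on a saturated chain carbon, six bonds along the chain from an oxygen on an aromatic ring. Going by the values given here, the one measured step that bears on this change is the one in which a hydroxyl-bearing piperidinyl ring replaced the same dimethylamino group at the same place, giving a 1.6-fold lower number from compound 2 to compound 3 (0.19 log units; within the scatter), a change within the scatter. The change to compound 4 brings in the plain ring without the hydroxyl, so no shift beyond the scatter is expected in this assay, with at most a slight drift toward a lower number. Compound 4 is therefore expected to give about 120 nM, most likely between 40 nM and 350 nM. That estimate means an expected step of a 1.6-fold lower number from compound 2 to compound 4 (0.19 log units; within the scatter).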

Compound 4, half-maximal inhibitory concentration: 54 nM
Beside the measured number, compound 4's estimate is 2.2-fold (0.35 log units) above it; low and high end bracket the measured number.
By their numbers in this assay, from the lowest: compounds 4, 1, 3 and 2 (each within the scatter of the next, the first and the last beyond it).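

In this assay, the change at the end of the chain now gives a step beyond the scatter, a 3.5-fold lower number from compound 2 to compound 4 (0.54 log units; beyond the scatter), whereas the hydroxyl-bearing ring of compound 3 had stayed within the scatter of compound 2. The hydroxy group on the ring also makes a measurable difference here: hydrogen in its place on a saturated ring carbon gives a 2.2-fold lower number from compound 3 to compound 4 (0.35 log units; beyond the scatter), so the two piperidine rings do not read alike in this assay. Nothing measured here accounts for either step.

As far as these compounds go, whether other ring amines at the chain end, such as morpholine or pyrrolidine, would give similar numbers remains open. From the compounds shown here alone, compound 1 differs from compound 3 and compound 4 in more than one place, so the separate contributions of chain length and of where the chain sits on the core also remain open.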